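Moving the methyl on the benzamide ring of compound 3

The source may report more compounds than this note shows. Statements on the series, on what has been measured and on what is new or still open speak of the compounds shown alone.

Measured so far:
compound 1 `Cc1ccc(C(=O)Nc2sc3c(c2C(N)=O)CCN(Cc2c(Cl)cccc2Cl)C3)cc1` gives 10000 nM
compound 2 `NC(=O)c1c(NC(=O)c2ccccc2I)sc2c1CCN(C(=S)Nc1ccccc1Cl)C2` gives 8560 nM
compound 3 `Cc1ccccc1C(=O)Nc1sc2c(c1C(N)=O)CCN(C(=S)Nc1ccccc1Cl)C2` gives 20900 nM

All three were tested in a functional assay on HL-60 cells (Homo sapiens) for antiproliferative activity, with a stated time of 24 h; on this read-out lower numbers stand for stronger inhibition and higher numbers for weaker inhibition. Compound 3 has the highest number of the three, with compound 1 nearest and compound 2 furthest. Compound 4 `Cc1ccc(C(=O)Nc2sc3c(c2C(N)=O)CCN(C(=S)Nc2ccccc2Cl)C3)cc1` differs from compound 3 in one place: 4-methylphenyl in place of 2-methylphenyl on a carbonyl carbon. Going by the values given here, the only measured step, a 2.4-fold higher number from compound 2 to compound 3 (0.39 log units; beyond the scatter), swaps one group for another and says nothing about moving the methyl around the ring. Compound 4 carries the same 4-methylphenyl as compound 1, which differs elsewhere too, so the value of compound 1, 10000 nM, is only a loose guide. A step of a 1.6-fold lower number from compound 3 to compound 4 (0.21 log units; within the scatter) is therefore expected, within the usual scatter. Compound 4 is estimated at 13000 nM, between 5000 nM and 35000 nM.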

Compound 4, half-maximal inhibitory concentration: 8430 nM
Compound 4: the middle estimate sits 1.5-fold (0.19 log units) above what was measured; measured number inside the range.
By their numbers in this assay, from the lowest: compounds 4, 2 and 1 (each within the scatter of the next); then compound 3.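

In this assay, shifting the methyl from 2-methylphenyl to 4-methylphenyl gives a 2.5-fold lower number from compound 3 to compound 4 (0.39 log units; beyond the scatter), so with the same atoms joined differently, where the methyl sits on this ring changes the result for this pair. Two other single changes stay within the scatter: 4-methylphenyl in place of 2-iodophenyl gives a 1.0-fold lower number from compound 2 to compound 4 (0.01 log units; within the scatter), and changing the group on the ring amine nitrogen gives a 1.2-fold lower number from compound 1 to compound 4 (0.07 log units; within the scatter). Nothing measured here explains the effect of moving the methyl.

Still open, going by these compounds, is whether a larger shift would follow from replacing the methyl of the 4-methylphenyl with an amine or a carboxylic acid.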